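Moving the Fluorine Around the Sulfonyl Ring

A few compounds are considered here, and "the series" means these few. Any claim that something is new, unique, unknown or untested is made for them only; others in the source may bear on it.

Of the compounds shown here, two have been measured in an assay on MDA-MB-231 cells for displacement of a labelled ligand from C-X-C chemokine receptor type 4 (Homo sapiens), read by fluorescence and microscopy, with stated times of 10 min and 30 min; on this read-out lower numbers stand for an effect already at smaller amounts and higher numbers for an effect only at larger amounts of compound. Compound 1 `COc1ccccc1C(=O)NCc1ccc(CNS(=O)(=O)c2cccc(Cl)c2)cc1` gives 1000 nM. Compound 2 `COc1ccccc1C(=O)NCc1ccc(CNS(=O)(=O)c2ccccc2F)cc1` gives 1 nM. Compound 2 thus holds the lowest of the two numbers seen so far, and the gap to compound 1 is large: a 1000-fold lower number from compound 1 to compound 2 (3.00 log units; beyond the scatter). Among the compounds with values here, that single step is the only comparison available, and it changed two things at once, the halogen and its place on the ring, so neither share can be separated out.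

Compound 3 `COc1ccccc1C(=O)NCc1ccc(CNS(=O)(=O)c2ccc(F)cc2)cc1` is not yet measured. It differs from compound 2 in one place: 4-fluorophenyl in place of 2-fluorophenyl on a sulfonyl sulfur. The fluorine stays, only its place on the ring moves. The step from compound 1 to compound 2 shows that the substitution pattern of this ring can shift the number a great deal, so a step beyond the scatter is expected here too, though its direction cannot be fixed from one comparison. Because compound 2 sits at 1 nM, the lowest number measured, a move towards higher numbers is judged more likely, and the expected step is a 30-fold higher number from compound 2 to compound 3 (1.48 log units; beyond the scatter). Compound 3 is therefore estimated at 30 nM in this assay, with a range from 2 nM to 500 nM.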

Compound 3, effective concentration (reported as EC, without a stated level of effect): 100 nM
The estimate for compound 3 lay 3.3-fold (0.52 log units) below the measured number; measured number inside the range.
By their numbers in this assay, from the lowest: compound 2; then compound 3; then compound 1.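

Moving the fluorine and changing nothing else gives a 100-fold higher number from compound 2 to compound 3 (2.00 log units; beyond the scatter) in this assay, so the place of a halogen on this ring matters on its own, even though the atoms stay the same. The other new comparison gives a 10-fold lower number from compound 1 to compound 3 (1.00 log units; beyond the scatter), which shows that the 4-fluorophenyl group also differs clearly from the 3-chlorophenyl group; however, this step, like the first one measured, changes the halogen and its place together, so it cannot say how much each contributes. No supporting measurement is available to explain why these changes shift the number.

The compounds shown leave open how a 3-fluorophenyl group would compare, which would separate the effect of fluorine against chlorine from the effect of place, and how a 2-chlorophenyl group would compare with the 2-fluorophenyl group of compound 2. They also leave open whether any halogen is needed, since a plain phenyl group on the sulfonyl sulfur would show what the ring gives without one.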